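The source may report more compounds than this note shows. Statements on the series, on what has been measured and on what is new or still open speak of the compounds shown alone.

Measured in an ADME assay on PBMC cells (Homo sapiens) for cytotoxicity; on this read-out lower numbers stand for higher toxicity in this test and higher numbers for lower toxicity in this test:
compound 1 `CC(CCNC(=O)c1c(Cl)cncc1Cl)N1CCC(C(Oc2cccc(C(=O)O)n2)c2ccc(C(F)(F)F)cc2)CC1`: 28700 nM
compound 2 `CC(CCNC(=O)c1c(Cl)cncc1Cl)N1CCC(C(Oc2cccc(F)c2)c2ccc(C(F)(F)F)cc2)CC1`: 5400 nM
compound 3 `CCO/N=C(/c1ccc(Br)cc1)C1CCN(C(C)CCNC(=O)c2c(C)cc[n+]([O-])c2C)CC1`: > 177000 nM (a limit)

Compound 2 has the lower of the two actual numbers, with the gap between them given by a 5.3-fold lower number from compound 1 to compound 2 (0.73 log units; beyond the scatter). The result for compound 3 is a limit and gives no exact place in that order.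

The next compound is compound 4 `Cc1cccnc1OC(c1ccc(C(F)(F)F)cc1)C1CCN(C(C)CCNC(=O)c2c(Cl)cncc2Cl)CC1`, with this change from compound 2: 3-methylpyridin-2-yl in place of 3-fluorophenyl on an oxygen on a saturated carbon. In words, 3-methylpyridin-2-yl stands in place of 3-fluorophenyl on an oxygen on a saturated carbon. Going by the values given here, the only measured step at this place is a 5.3-fold lower number from compound 1 to compound 2 (0.73 log units; beyond the scatter), a modest one. It bears only loosely on the new change, since it involves 6-carboxypyridin-2-yl, a group that compound 4 does not carry. No step beyond the scatter is therefore expected in this assay, though a slightly higher number would not surprise. The expected step is a 1.2-fold higher number from compound 2 to compound 4 (0.08 log units; within the scatter). For compound 4 the estimated value is 6500 nM, with an expected range of 3000 nM to 15000 nM.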

Compound 4, half-maximal cytotoxic concentration: 33000 nM
Beside the measured number, compound 4's estimate is 5.1-fold (0.71 log units) below it, and the stated range ends below it.
By their numbers in this assay, from the lowest: compound 2; then compounds 1 and 4 (each within the scatter of the next). At a limit, above all of these: compound 3.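

In this assay, going by these compounds alone, the swap on this oxygen gives a step beyond the scatter (a 6.1-fold higher number from compound 2 to compound 4 (0.79 log units; beyond the scatter)), which the earlier compounds could not show for a group without a carboxylic acid. Compound 4 carries no carboxylic acid, yet the two pyridine compounds lie within the scatter of each other (a 1.1-fold higher number from compound 1 to compound 4 (0.06 log units; within the scatter)), so the carboxyl group of compound 1 is not needed for a number at this level. Among the three compounds that differ only at this place, compound 2 with its 3-fluorophenyl stands apart from both pyridine-bearing compounds.

The step to compound 4 cannot yet be split between the ring nitrogen and the methyl group, and a 3-methylphenyl or a 3-fluoropyridin-2-yl group on this oxygen would separate the two. No measurement shown here accounts for the step.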